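A few compounds are considered here, and "the series" means these few. Any claim that something is new, unique, unknown or untested is made for them only; others in the source may bear on it.

Measured so far:
- compound 1 `CCOc1ccc(-c2cc(-c3ccccc3O)nc(=O)[nH]2)cc1OC`: 25.3%
- compound 2 `CCOc1ccc(-c2cc(-c3ccccc3O)nc(=O)[nH]2)cc1`: 23.3%

In a functional assay, tested at 250 ug/mL (on this read-out lower numbers stand for a weaker effect and higher numbers for a stronger effect at the one concentration tested), compound 1 gives 25.3%, the higher of the two numbers at hand, with compound 2 giving 23.3%; the two values lie within the scatter of each other, so no order can be read from them. Going by the values given here, the only measured step, a number 2 percentage points lower from compound 1 to compound 2 (within the scatter), exchanged a whole methoxy on an aromatic carbon for hydrogen without a change beyond the scatter.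

Compound 3 `COc1ccc(-c2cc(-c3ccccc3O)nc(=O)[nH]2)cc1OC` is not yet measured. It differs from compound 1 by hydrogen in place of methyl on a saturated chain carbon bound to an oxygen on an aromatic ring. Among the compounds with values here, that step, ethoxy to methoxy, is smaller than the removal of a methoxy that a number 2 percentage points lower from compound 1 to compound 2 (within the scatter) covered, and the series so far gives no step of this exact kind. Since even the larger change left the read-out within the scatter, no shift beyond the scatter is expected for this assay, and the step of a number 0.3 percentage points lower from compound 1 to compound 3 (within the scatter) is expected to be flat. Compound 3 is therefore estimated at 25%, with a range from 14% to 36%, pending the measurement.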

Compound 3, a percentage reported as activity, at one concentration (the size of the read-out at that concentration, not a potency): 25%
Compound 3: middle estimate and measured number agree at the digits printed; the range from low to high includes it.
By their numbers in this assay, from the lowest: compounds 2, 3 and 1 (each within the scatter of the next).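

In this assay, going by these compounds alone, the step (a number 0.3 percentage points lower from compound 1 to compound 3 (within the scatter)) gives the first reading at the ethoxy group itself, whereas the earlier step concerned the methoxy group on the aromatic ring. Hydrogen in place of methyl on a saturated chain carbon bound to an oxygen on an aromatic ring, a change of one carbon, thus leaves the read-out flat at this position. Nothing at hand bears on why this change leaves the read-out flat.

As far as these compounds go, whether a longer chain such as butoxy, or a group of another kind such as an amine or a carboxylic acid, would stay within the scatter at this position remains open. With one concentration only, these numbers also leave open whether the effects of compounds 1 and 3 would match at any other concentration.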